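A few compounds are considered here, and "the series" means these few. Any claim that something is new, unique, unknown or untested is made for them only; others in the source may bear on it.

Of the compounds shown here, two from this series have so far been tested in an assay on CHO cells for displacement of a labelled ligand from Alpha-2C adrenergic receptor (Homo sapiens); on this read-out higher numbers stand for weaker inhibition and lower numbers for stronger inhibition. Compound 1 `CC(Oc1ccccc1-c1cccnc1)C1=NCCN1` gives 64.6 nM in this assay. Within the data shown here, compound 2 `Cc1cccc(-c2ccccc2OC(C)C2=NCCN2)c1` gives 245 nM in this assay, the higher of the two numbers measured, and the only step recorded so far is a 3.8-fold higher number from compound 1 to compound 2 (0.58 log units; beyond the scatter), a change at the same aromatic carbon that compound 3 alters.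

Compound 3 `CC(Oc1ccccc1-c1ccc(O)cc1)C1=NCCN1` has not yet been measured. It differs from compound 2 in one place: 4-hydroxyphenyl in place of 3-methylphenyl on an aromatic carbon. Among the measured compounds shown here, the one measured step, a 3.8-fold higher number from compound 1 to compound 2 (0.58 log units; beyond the scatter), does not involve a hydroxyl-bearing ring, so it gives only indirect guidance: it shows that the group at this position matters beyond the scatter, and that the plain hydrocarbon ring of compound 2 gave the weaker result of the two. Since compound 3 again replaces that hydrocarbon ring with one carrying a hydrogen-bond donor and acceptor, a modest fall in the number is expected, a 2.0-fold lower number from compound 2 to compound 3 (0.31 log units; beyond the scatter), with wide uncertainty. The estimate for compound 3 in this assay is therefore 120 nM, within a range of 40 nM to 400 nM.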

Compound 3, inhibition constant: 331 nM
Beside the measured number, compound 3's estimate is 2.8-fold (0.44 log units) below it; measured number inside the range.
By their numbers in this assay, from the lowest: compound 1; then compounds 2 and 3 (each within the scatter of the next).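

In this assay, the step from 3-methylphenyl to 4-hydroxyphenyl is a 1.4-fold higher number from compound 2 to compound 3 (0.13 log units; within the scatter), so on this read-out these two rings cannot be told apart, even though the entering group brings a hydrogen-bond donor and acceptor that the leaving group lacks. The pyridin-3-yl ring of compound 1 now stands apart from two different rings of carbon only: besides a 3.8-fold higher number from compound 1 to compound 2 (0.58 log units; beyond the scatter), there is a 5.1-fold higher number from compound 1 to compound 3 (0.71 log units; beyond the scatter), and both steps lie beyond the scatter, which leaves compound 1 with the lowest number of the three. Nothing available here explains this difference between the rings, so the numbers record it without accounting for it.

As their names show, 3-methylphenyl and 4-hydroxyphenyl differ both in the group they carry and in where they carry it, so these compounds cannot show what either change does alone. They also leave open how a plain phenyl ring would compare, and whether a ring carrying an amine or a carboxylic acid would fall nearer to compound 1 or to the two rings of carbon only tested here.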